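Swapping 2-fluorophenyl for cyclopropyl at the assay limit

The source may hold more compounds than are shown below. What is called first, only, known or untested is meant among the compounds shown, and "the series" means these compounds.

In a functional assay on KYSE-70 cells for antiproliferative activity against KYSE-70 cell line (Homo sapiens), read by MTT assay, with a stated time of 72 h (on this read-out higher numbers stand for weaker inhibition and lower numbers for stronger inhibition), compound 1 `CC(=O)c1ccc(-c2ccc3c(C(=O)Nc4cccc(F)c4)cc(=O)[nH]c3c2)cc1` gives > 20000 nM, which is a limit of the assay and not a number. In this assay compound 2 `O=C(Nc1cccc(F)c1)c1cc(=O)[nH]c2cc(-c3ccccc3F)ccc12` gives > 20000 nM, and this too is a limit. Going by the values given here, the only measured step, a step that the two limits leave unreadable from compound 1 to compound 2, therefore has no readable size. Among the compounds with values here, all that the data so far offer is the limit of > 20000 nM in this assay, at which 2 of the 2 values shown sit, so compound 2 stands level with the only other measured compound, and no true potency is known for either.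

Compound 3 `O=C(Nc1cccc(F)c1)c1cc(=O)[nH]c2cc(C3CC3)ccc12` keeps the shared core but carries a new group: cyclopropyl in place of 2-fluorophenyl on an aromatic carbon. In words, this is cyclopropyl in place of 2-fluorophenyl on an aromatic carbon. A change on this same carbon left compound 2 at > 20000 nM, a limit, so no clear gain is expected for compound 3. The expected change is a number no higher from compound 2 to compound 3 (the limit leaves the size open), with no step beyond the scatter foreseen in either direction. For compound 3 the estimated value is 20000 nM, with an expected range from 9000 nM to 40000 nM, and the assay may well report only a limit again.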

Compound 3, half-maximal inhibitory concentration: > 20000 nM
Compound 3 ended at the assay's limit (the forecaster's own chance of this, stated with the estimate: 75%); the middle value lies on the limit itself.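

In this assay compound 3 gives > 20000 nM, which is a limit of the assay and not a number. Going by these compounds alone, no step among compound 1, compound 2 and compound 3 can therefore be read, and the data show only this: the limit of > 20000 nM in this assay, at which 3 of the 3 values shown sit. As far as these compounds go, the true potency of all three compounds stays open, as does whether any group on this aromatic carbon would give a readable value.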